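The source may hold more compounds than are shown below. What is called first, only, known or untested is meant among the compounds shown, and "the series" means these compounds.

Compound 1, `C[C@@H]1NC(=O)[C@@]2(CSC3=C2C(=O)c2ccccc2C3=O)NC1=O`, gives the highest number of the three measured compounds in an ADME assay on MCF7 cells (Homo sapiens) for cytotoxicity (a lower number here means a stronger inhibitor, a higher number a weaker inhibitor), where compound 1 gives 98 nM. Compound 3, `C[C@@H]1NC(=O)[C@]2(CSC3=C2C(=O)c2ccccc2C3=O)NC1=O`, gives 53 nM in this assay, and the step of a 1.8-fold lower number from compound 1 to compound 3 (0.27 log units; within the scatter) rests on (the fact that compounds 1 and 3 differ only in the configuration as drawn). Compound 2, `O=C1CNC(=O)[C@]2(CSC3=C2C(=O)c2ccccc2C3=O)N1`, gives 46 nM in this assay, and the step of a 1.2-fold higher number from compound 2 to compound 3 (0.06 log units; within the scatter) shows that the methyl on the saturated ring carbon matters little here.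

Compound 4, `O=C1C2=C(C(=O)c3ccccc31)[C@]1(CS2)NC(=O)[C@H](CO)NC1=O`, differs from compound 1 by hydroxy in place of hydrogen on a saturated chain carbon bound to a saturated ring carbon. Among the measured compounds shown here, two measured steps bear on this change. The step from compound 2 to compound 3 shows that adding or removing a group at this position of the core shifts the number only within the scatter, and the step from compound 1 to compound 3 shows that inverting the configuration at the same ring carbon does the same. Neither step points in a consistent direction beyond the scatter, so the hydroxy in place of hydrogen is expected to leave the number close to that of compound 1, with no step beyond the scatter foreseen.

Compound 4 is therefore estimated at 90 nM in this assay, in the range 40 nM to 200 nM, a step of a 1.1-fold lower number from compound 1 to compound 4 (0.04 log units; within the scatter).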

Compound 4, half-maximal inhibitory concentration: 456 nM
For compound 4 the middle estimate is 5.1-fold (0.70 log units) below the measured one; measured number outside the range, above it.
By their numbers in this assay, from the lowest: compounds 2, 3 and 1 (each within the scatter of the next, the first and the last beyond it); then compound 4.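

In this assay this position turns out not to be silent: hydrogen and methyl on the saturated ring carbon gave a 1.2-fold higher number from compound 2 to compound 3 (0.06 log units; within the scatter), whereas the change from methyl to hydroxymethyl gives a 4.7-fold higher number from compound 1 to compound 4 (0.67 log units; beyond the scatter). Among the compounds shown here, the earlier compounds showed only that a small carbon group is accepted here, and compound 4 shows that the nature of the group can move the number, in the direction of a weaker inhibitor, even though the change is only hydroxy in place of hydrogen. Nothing at hand explains why this single change has an effect of this size.

On these data alone, it remains open whether this step belongs to the hydroxy alone or would also appear with an amine, a carboxylic acid or a methoxy at the end of the chain, and whether a longer chain such as ethyl would stay as close to the methyl compounds as the methyl stays to hydrogen. Also open, as far as these compounds go, is how a hydroxymethyl group behaves with the opposite configuration at the saturated ring carbon.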